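The source may report more compounds than this note shows. Statements on the series, on what has been measured and on what is new or still open speak of the compounds shown alone.

Measured so far:
Compound 1 `Cc1cccc(Cn2c(CN3CCN(C(=O)C4CCCC4)CC3)nc3ccccc32)c1` gives 67.5% in an assay on isolated protein for inhibition of aldehyde dehydrogenase 1A1 (Homo sapiens), read by spectrophotometry, tested at 10 uM; on this read-out lower numbers stand for less inhibition and higher numbers for more inhibition at the one concentration tested (going by the name of the read-out).
Compound 2 `Cc1cccc(Cn2c(CN3CCN(C(=O)c4ccc(C(F)(F)F)cc4)CC3)nc3ccccc32)c1` gives 22.9% in this assay.
Compound 3 `Cc1cccc(Cn2c(CN3CCN(C(=O)c4ccc(C(C)C)cc4)CC3)nc3ccccc32)c1` gives 67.6% in this assay.

Compound 3 holds the highest of the three numbers, but its gap to compound 1 is within the scatter, a number 0.1 percentage points higher from compound 1 to compound 3 (within the scatter), so the two cannot be told apart; only compound 2 sits clearly lower, a number 44.7 percentage points higher from compound 2 to compound 3 (beyond the scatter). Compound 4 `Cc1cccc(Cn2c(CN3CCN(C(=O)c4ccc(C#N)cc4)CC3)nc3ccccc32)c1` differs from compound 3 in one place: cyano in place of isopropyl on an aromatic carbon.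

Within the data shown here, two measured steps bear on this. Replacing the cyclopentyl with a 4-(trifluoromethyl)phenyl gave a large drop, a number 44.6 percentage points lower from compound 1 to compound 2 (beyond the scatter), and swapping that trifluoromethyl for isopropyl restored it, a number 44.7 percentage points higher from compound 2 to compound 3 (beyond the scatter). So the group on that aromatic carbon matters strongly, and the only alternative to isopropyl measured there gave a much lower number. Cyano has not been tried, so its direction is uncertain, but a sizeable step downward is the more likely outcome.

Compound 4 is therefore expected to give about 38% in this assay, within 12% to 65%, an estimated step of a number 29.6 percentage points lower from compound 3 to compound 4 (beyond the scatter).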

Compound 4, a percentage reported as inhibition, at one concentration (the size of the read-out at that concentration, not a potency): 20.8%
Beside the measured number, compound 4's estimate is 17.2 percentage points above it; the measured number falls inside the stated range.
By their numbers in this assay, from the lowest: compounds 4 and 2 (each within the scatter of the next); then compounds 1 and 3 (each within the scatter of the next).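

In this assay, the fall seen with trifluoromethyl now has a second example on the same aromatic carbon: cyano gives a large step down from isopropyl (a number 46.8 percentage points lower from compound 3 to compound 4 (beyond the scatter)) and cannot be told apart from trifluoromethyl (a number 2.1 percentage points lower from compound 2 to compound 4 (within the scatter)). The 4-cyanophenyl also stands well apart from the cyclopentyl on the carbonyl carbon (a number 46.7 percentage points lower from compound 1 to compound 4 (beyond the scatter)), so among these four compounds, the 4-isopropylphenyl alone of the three substituted phenyl groups stays level with the cyclopentyl. No evidence at hand explains why isopropyl parts from the other two groups here.

Still open, from the compounds shown here alone, is how other groups on this aromatic carbon would read, such as a methoxy, an amine or a carboxylic acid. A tert-butyl or a longer chain in place of isopropyl would show whether the high number extends beyond isopropyl itself.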